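The compounds below may be only part of what the source reports. "The series", "measured", "known", "first", "only" and "open" are said of these compounds alone.

Working notes on the series, read in a functional assay on A549 cells (Homo sapiens) for antiproliferative activity, with a stated time of 72 h; a lower number here means a stronger inhibitor, a higher number a weaker inhibitor. Compound 1 `CC(=O)Oc1ccc(/C=C/c2nc3ccccc3c(=O)[nH]2)c(OC(C)=O)c1` gives > 25000 nM, which is a limit. Compound 3 `COc1ccccc1/C=C/c1nc2ccccc2c(=O)[nH]1` gives > 25000 nM, which is also a limit. Compound 2 `COc1ccccc1/C=C/c1nc(Nc2ccccc2Cl)c2ccccc2n1` gives > 25000 nM, again a limit. Compound 2 therefore has no number of its own, and it stands level with the other two measured compounds: the whole set sits at the limit of > 25000 nM in this assay, at which 3 of the 3 values shown sit. Among the measured compounds shown here, no step between measured compounds exists, so nothing can be ranked yet.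

The next compound, compound 4 `COc1ccccc1/C=C/c1nc(Nc2ccc(O)cc2)c2ccccc2n1`, keeps the core and the rest of compound 2 and changes one group: 4-hydroxyphenyl in place of 2-chlorophenyl on a nitrogen on an aromatic ring. In words, 4-hydroxyphenyl stands in place of 2-chlorophenyl on a nitrogen on an aromatic ring, so (2-chlorophenyl)amino becomes (4-hydroxyphenyl)amino.

With every measured compound at the limit, the data give no sign of any strong response in this series, and the expectation stays cautious. The expected step of an at least 1.7-fold lower number from compound 2 to compound 4 (0.25 log units; that floor lies within the scatter) is a small one towards stronger inhibition, hardly beyond the scatter, and the assay may again report only a limit. For compound 4 the estimated value is 14000 nM, with an expected range of 3000 nM to 25000 nM.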

Compound 4, half-maximal inhibitory concentration: 13000 nM
Compound 4: the middle estimate sits 1.1-fold (0.03 log units) above what was measured; measured number inside the range.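

In this assay, among the compounds shown here, 4-hydroxyphenyl in place of 2-chlorophenyl on a nitrogen on an aromatic ring gives an at least 1.9-fold lower number from compound 2 to compound 4 (0.28 log units; that floor lies within the scatter), the first step that can be read, though its floor does not clear the scatter. As far as these compounds go, compound 2 gives > 25000 nM, which is a limit, so the printed step is only a floor and its full size remains unknown. The group on this nitrogen is thus the one place so far where a change goes with a number rather than a limit, and compound 4 alone stands apart from the rest of the set: the limit of > 25000 nM in this assay, at which 3 of the 4 values shown sit.

The compounds shown do not separate the departure of 2-chlorophenyl from the arrival of 4-hydroxyphenyl, so it stays open which side of the change matters. From the compounds shown here alone, whether 4-methoxyphenyl, 4-aminophenyl or 4-carboxyphenyl on the same nitrogen would also give a number in this assay, and whether any such group could move the read-out clearly beyond the scatter, also remains open.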